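A few compounds are considered here, and "the series" means these few. Any claim that something is new, unique, unknown or untested is made for them only; others in the source may bear on it.

Measured so far:
compound 1 `C[C@@H](Nc1c(C(=O)NCc2ccc(F)cc2)nc(Br)c2cccnc12)c1ccccc1` — "not determined" (no result reported)
compound 2 `N[C@H]1CC[C@H](Nc2c(C(=O)NCc3cccs3)nc(Br)c3cccnc23)CC1` — 7300 nM

In a functional assay on MCF7 cells (Homo sapiens) for cytotoxicity, read by MTT assay, with a stated time of 72 h (a higher number here means a weaker inhibitor, a lower number a stronger inhibitor), compound 1 stands without a number, so nothing on the shared core places it. Compound 2 in this assay gives 7300 nM, the only figure the series holds. Compound 3 `COC(=O)CNc1c(C(=O)NCc2ccc(F)cc2)nc(Br)c2cccnc12` is still to be tested; it differs from compound 1 in one place: (methoxycarbonyl)methyl in place of 1-phenylethyl on a nitrogen on an aromatic ring. Among the measured compounds shown here, with no measured step in this assay to lean on, a modest loss is expected rather than none, though the scatter could hide it. For compound 3 in this assay an inhibitory concentration of about 15000 nM is estimated, within 3000 nM to 60000 nM.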

Compound 3, half-maximal inhibitory concentration: > 10000 nM
Compound 3: only a limit was reported (the forecaster's own chance of this, stated with the estimate: 30%); the middle value is on the limit's open side.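

Among the compounds shown here, compound 1 has no number, so no step to compound 3 can be read. In this assay compound 3 gives > 10000 nM, which is a limit and not a number. The compounds shown leave open how far (methoxycarbonyl)methyl in place of 1-phenylethyl shifts potency in this assay.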